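This account rests on a few compounds, and the source may have more. Where it says the series, first, only, none or still open, it means among the compounds named here.

Measured in an ADME assay on MDCK cells (Canis lupus familiaris) for cytotoxicity; a higher number here means that more compound is tolerated, a lower number that less compound is tolerated:
- Compound 1 `CC(=O)Nc1ccc2oc(-c3ccnc(C(=O)N4CCN(C(c5cccc(F)c5)c5nnn(C)n5)CC4)c3)nc2c1`: > 50000 nM
- Compound 2 `CC(=O)Nc1ccc2oc(-c3ccnc(C(=O)N4CCN(C(c5ccc(Br)cc5)c5nnn(C)n5)CC4)c3)nc2c1`: > 50000 nM
- Compound 3 `CC(=O)Nc1ccc2oc(-c3ccnc(C(=O)N4CCN(C(c5ccc(C)cc5)c5nnn(C)n5)CC4)c3)nc2c1`: > 50000 nM

All three entries are limits of the assay, not numbers. Going by the values given here, the series so far shows (the limit of > 50000 nM in this assay, at which 3 of the 3 values shown sit).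

Compound 3 stands at > 50000 nM, which is a limit.

The next compound is compound 4 `CC(=O)Nc1ccc2oc(-c3ccnc(C(=O)N4CCN(C(c5ccc([N+](=O)[O-])cc5)c5nnn(C)n5)CC4)c3)nc2c1`, with nitro in place of methyl on an aromatic carbon.

The measured steps that bear on this change are those on the same aromatic ring: a step that the two limits leave unreadable from compound 2 to compound 3, a step that the two limits leave unreadable from compound 1 to compound 2 and a step that the two limits leave unreadable from compound 1 to compound 3. Among the compounds with values here, none of them has a readable size, and no measured compound carries a nitro group. These steps therefore give no basis for expecting a direction in this assay.

this assay is thus expected to show no step beyond the scatter, and the estimated step is a number no higher from compound 3 to compound 4 (the limit leaves the size open).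

A further limit is the most likely report. As a value, compound 4 is expected at 50000 nM, with an estimated range of 20000 nM to 100000 nM.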

Compound 4, half-maximal cytotoxic concentration: > 50000 nM
Compound 4: only a limit was reported (the forecaster's own chance of this, stated with the estimate: 85%); the middle value lies on the limit itself.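

In this assay, going by these compounds alone, compound 4 gives > 50000 nM, a limit and not a number, so no step between compound 4 and compound 1, compound 2 or compound 3 can be read. The compounds shown leave open whether any of these ring changes alters tolerance at all, since the series rests on one limit: the limit of > 50000 nM in this assay, at which 4 of the 4 values shown sit.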